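The source may report more compounds than this note shows. Statements on the series, on what has been measured and on what is new or still open speak of the compounds shown alone.

Compounds measured in a functional assay on B16 cells (Mus musculus) for antiproliferative activity, with a stated time of 72 h; on this read-out higher numbers stand for weaker inhibition and lower numbers for stronger inhibition:
compound 1 `CSc1cnc2ccccc2c1[Se]CC#CCCl`: 3.5 ug/mL
compound 2 `OCC#CCSc1cnc2ccccc2c1[Se]CC#CCCl`: 3.8 ug/mL

Going by the values given here, compound 1 holds the lowest of the two numbers; its only neighbour is compound 2, a 1.1-fold higher number from compound 1 to compound 2 (0.04 log units; within the scatter), so the two values lie within the scatter of each other. Compound 3 `CSc1cnc2ccccc2c1SCC#CCO` has not yet been measured in this assay. It differs from compound 1 in one place: a group of 6 heavy atoms (4 carbon, 1 oxygen, 1 sulfur; no ring) in place of a group of 6 heavy atoms (4 carbon, 1 chlorine, 1 selenium; no ring), on an aromatic carbon. Among the compounds with values here, the single measured step, a 1.1-fold higher number from compound 1 to compound 2 (0.04 log units; within the scatter), concerns 3-hydroxyprop-1-yn-1-yl in place of hydrogen on a saturated chain carbon bound to a sulfur and leaves the group on the aromatic carbon untouched, so it does not bear on this change, and no measured pair replaces the selenium-containing group. The expectation therefore rests on compound 1 alone and carries a wide range. Compound 3 is expected to give 5 ug/mL, between 2 ug/mL and 15 ug/mL, an estimated step of a 1.4-fold higher number from compound 1 to compound 3 (0.15 log units; within the scatter) that is not expected to exceed the scatter.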

Compound 3, concentration for 50% inhibition: 49.8 ug/mL
The estimate for compound 3 lay 10-fold (1.00 log units) below the measured number; measured number outside the range, above it.
By their numbers in this assay, from the lowest: compounds 1 and 2 (each within the scatter of the next); then compound 3.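

Within this assay the group on the aromatic carbon opposite the ring nitrogen proves sensitive to change, with the exchange of the chlorine- and selenium-bearing group for the oxygen- and sulfur-bearing group giving a 14-fold higher number from compound 1 to compound 3 (1.15 log units; beyond the scatter) on the shared core. Going by these compounds alone, the earlier variation on the methylsulfanyl group gave no such separation, so this aromatic position is the first place where a change exceeds the scatter, even though both groups have 6 heavy atoms, no ring and 1 triple bond. Nothing at hand explains the loss.

Going by these compounds, the exchange alters selenium and chlorine together, so their separate shares stay open, and a selenium-bearing group ending in hydroxyl or a sulfur-bearing group ending in chlorine would divide them. On these data alone, whether an amine or a longer chain in this position is tolerated also remains open.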